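Swapping the Sulfonamide Amine on a Potassium-Channel Series

The source may hold more compounds than are shown below. What is called first, only, known or untested is meant among the compounds shown, and "the series" means these compounds.

Compound 1 `CCC(C)N(C(C)CC)S(=O)(=O)c1ccc(NC(=O)C(C)(O)C(F)(F)F)cc1`: > 30000 nM
Compound 2 `CN(C)S(=O)(=O)c1ccc(NC(=O)C(C)(O)C(F)(F)F)cc1`: 480 nM

Within the data shown here, in an assay on a protein complex (Cavia porcellus) with sulfonylurea receptors; K-ATP channels (Homo sapiens) as the target (on this read-out lower numbers stand for stronger inhibition and higher numbers for weaker inhibition), compound 2 gives 480 nM, the only plain number so far. For compound 1 the assay reports only a limit, (the limit of > 30000 nM in this assay, at which 1 of the 2 values shown sits). Among the measured compounds shown here, the single measured step, an at least 62-fold lower number from compound 1 to compound 2 (1.79 log units; beyond the scatter), shows that the amine on the sulfonyl sulfur carries a large effect. Compound 3 `CC(O)(C(=O)Nc1ccc(S(=O)(=O)N2CCSCC2)cc1)C(F)(F)F` differs from compound 2 by thiomorpholin-4-yl in place of dimethylamino on a sulfonyl sulfur. Because the change sits at the same place as an at least 62-fold lower number from compound 1 to compound 2 (1.79 log units; beyond the scatter), a step of a 4.2-fold higher number from compound 2 to compound 3 (0.62 log units; beyond the scatter) toward weaker inhibition is expected for compound 3. Compound 3 is therefore estimated at 2000 nM, likely between 500 nM and 10000 nM.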

Compound 3, half-maximal inhibitory concentration: 4580 nM
Beside the measured number, compound 3's estimate is 2.3-fold (0.36 log units) below it; the range from low to high includes it.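

In this assay, thiomorpholin-4-yl on the sulfonyl sulfur loses clearly against dimethylamino (a 9.5-fold higher number from compound 2 to compound 3 (0.98 log units; beyond the scatter)), yet it still gains over bis(sec-butyl)amino (an at least 6.5-fold lower number from compound 1 to compound 3 (0.81 log units; beyond the scatter)). For compound 1 the assay gives only a limit: (the limit of > 30000 nM in this assay, at which 1 of the 3 values shown sits). The three amines thus fall into an order beyond the usual scatter, with dimethylamino giving the strongest inhibition, thiomorpholin-4-yl the middle and bis(sec-butyl)amino the weakest.

Still open, going by these compounds, is whether the ring sulfur matters, which morpholine, with oxygen there, or piperidine, with carbon, could help to separate. Methylamino, a smaller amine, also remains untested among the compounds shown.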